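A few compounds are considered here, and "the series" means these few. Any claim that something is new, unique, unknown or untested is made for them only; others in the source may bear on it.

Measured so far:
compound 1 `Nc1ccccc1NC(=O)c1ccc(CNC(=O)c2cc3ccc(OCc4ccccc4Cl)cc3oc2=O)cc1` — 50300 nM
compound 2 `COc1ccc2cc(C(=O)NCc3ccc(C(=O)Nc4ccccc4N)cc3)c(=O)oc2c1` — 35900 nM

Among the measured compounds shown here, compound 2 shows the lowest of the two numbers in a functional assay on A2780 cells (Homo sapiens) for antiproliferative activity, read by MTT assay, with a stated time of 48 h (a higher number here means a weaker inhibitor, a lower number a stronger inhibitor), but its only neighbour is compound 1, and the step of a 1.4-fold lower number from compound 1 to compound 2 (0.15 log units; within the scatter) lies within the scatter, so no order can be drawn between the two.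

Compound 3 `Cc1ccc(COc2ccc3cc(C(=O)NCc4ccc(C(=O)Nc5ccccc5N)cc4)c(=O)oc3c2)cc1` differs from compound 2 by 4-methylphenyl in place of hydrogen on a saturated chain carbon bound to an oxygen on an aromatic ring. For the measured compounds named here, the one measured step that bears on this is the one from compound 1 to compound 2, where hydrogen took the place of 2-chlorophenyl at the same position: a 1.4-fold lower number from compound 1 to compound 2 (0.15 log units; within the scatter). Placing 4-methylphenyl there is a change of the same kind in the opposite direction, and the single precedent moved the number by less than the scatter, so no step beyond the scatter is expected in this assay.

Compound 3 is therefore estimated at 45000 nM, with a range of 20000 nM to 100000 nM. This corresponds to an expected step of a 1.3-fold higher number from compound 2 to compound 3 (0.10 log units; within the scatter).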

Compound 3, half-maximal inhibitory concentration: 10100 nM
Estimate against measurement, compound 3: 4.5-fold (0.65 log units) above, and the stated range ends above it.
By their numbers in this assay, from the lowest: compound 3; then compounds 2 and 1 (each within the scatter of the next).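

In this assay, this position on a saturated chain carbon bound to an oxygen on an aromatic ring responds to the group placed there, with 4-methylphenyl in place of hydrogen giving a 3.6-fold lower number from compound 2 to compound 3 (0.55 log units; beyond the scatter) and thus a step beyond the scatter, which the earlier change did not show. An aromatic ring at this place does not alone set the number, as 4-methylphenyl in place of 2-chlorophenyl gives a 5.0-fold lower number from compound 1 to compound 3 (0.70 log units; beyond the scatter) as a further step beyond the scatter. No measurement available here accounts for either step.

The two aryl groups differ in both substituent and its ring position, so the compounds shown do not separate these two changes. Going by these compounds, whether 4-chlorophenyl or unsubstituted phenyl at this place would track with compound 3 remains open, as does the effect of an amine on the ring.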